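The source may hold more compounds than are shown below. What is called first, only, known or untested is meant among the compounds shown, and "the series" means these compounds.

Working notes on the series. All compounds share one core and differ only in the group on a saturated chain carbon bound to an oxygen next to a carbonyl group. Compound 1 `C=CCOC(=O)Nc1ccc([Se]C#N)cc1` gives 72800 nM in a functional assay on HT-29 cells (Homo sapiens) for cytotoxicity, read by MTT assay, with a stated time of 72 h; a higher number here means that more compound is tolerated, a lower number that less compound is tolerated. Compound 2 `CCCOC(=O)Nc1ccc([Se]C#N)cc1` gives 75400 nM in this assay, and compound 3 `N#C[Se]c1ccc(NC(=O)OCc2ccccc2)cc1` gives 69100 nM in this assay. The three numbers sit within the scatter of one another: a 1.0-fold higher number from compound 1 to compound 2 (0.02 log units; within the scatter), a 1.1-fold lower number from compound 1 to compound 3 (0.02 log units; within the scatter) and a 1.1-fold lower number from compound 2 to compound 3 (0.04 log units; within the scatter). Compound 3 is thus not separated from either neighbour, its nearest being compound 1 and its furthest compound 2, both within the scatter.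

Compound 4 `CCOC(=O)Nc1ccc([Se]C#N)cc1` differs from compound 3 in one place: methyl in place of phenyl on a saturated chain carbon bound to an oxygen next to a carbonyl group. Of the measured steps, the two that bring phenyl onto this position, a 1.1-fold lower number from compound 1 to compound 3 (0.02 log units; within the scatter) and a 1.1-fold lower number from compound 2 to compound 3 (0.04 log units; within the scatter), bear most directly on the change, being the reverse exchange of a short chain for phenyl; the step of a 1.0-fold higher number from compound 1 to compound 2 (0.02 log units; within the scatter) shows that an exchange between two short chains at this carbon also stays within the scatter. All three were within the scatter, so no step beyond the scatter is expected in this assay in either direction. Compound 4 is expected to give 72000 nM (range 48000 nM to 108000 nM), which means an expected step of a 1.0-fold higher number from compound 3 to compound 4 (0.02 log units; within the scatter).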

Compound 4, concentration lethal to 50% of the cells: 66600 nM
For compound 4 the middle estimate is 1.1-fold (0.03 log units) above the measured one; low and high end bracket the measured number.
By their numbers in this assay, from the lowest: compounds 4, 3, 1 and 2 (each within the scatter of the next).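

In this assay, methyl in place of phenyl on a saturated chain carbon bound to an oxygen next to a carbonyl group gives a 1.0-fold lower number from compound 3 to compound 4 (0.02 log units; within the scatter), so taking away the six-membered aromatic ring of carbon only, with five heavy atoms fewer in the group overall, leaves the read-out within the scatter. Within the data shown here, the chain steps agree: hydrogen in place of methyl on a saturated chain carbon, two bonds along the chain from an oxygen next to a carbonyl group, gives a 1.1-fold lower number from compound 2 to compound 4 (0.05 log units; within the scatter), and methyl in place of vinyl gives a 1.1-fold lower number from compound 1 to compound 4 (0.04 log units; within the scatter), so methyl, ethyl, vinyl and phenyl at this carbon are now all within the scatter of one another, with no compound of the four set apart. No measurement at hand offers a reason for this flat picture.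

Open, on these data alone, is whether a carboxylic acid, an amine or a much longer chain such as octyl on this carbon would also stay within the scatter. Also open, as far as these compounds go, is whether the same flat picture would hold in cells other than those of this assay.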